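This account rests on a few compounds, and the source may have more. Where it says the series, first, only, none or still open, it means among the compounds named here.

Working notes on the series.

Compound 1 `Cc1ccc2oc(-c3ccc(NC(=O)CN4CCN(CCN(C)C)CC4)c(C)c3)nc2c1` and compound 2 `Cc1cc(-c2nc3cc(Cl)ccc3o2)ccc1NC(=O)CN1CCN(CCN(C)C)CC1` share the amide-linked piperazine side chain. In a functional assay on C6 cells (Rattus norvegicus) for cytotoxicity, read by MTT assay, with a stated time of 24 h (a higher number here means a weaker inhibitor, a lower number a stronger inhibitor), compound 2 gives 13500 nM; compound 1 gives 16700 nM. The change methyl in place of chloro on an aromatic carbon gives a step of a 1.2-fold higher number from compound 2 to compound 1 (0.09 log units; within the scatter).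

Compound 3 `Cc1cc(-c2nc3cc(Cl)ccc3o2)ccc1NC(=O)CCl` carries a chloroacetamide instead. In this assay compound 3 gives only a limit, > 100000 nM, and the limit of > 100000 nM in this assay, at which 1 of the 3 values shown sits, marks where it sits. The difference between the core of compound 3 and the core of compound 2 is not broken down here.

Compound 4 `Cc1ccc2oc(-c3ccc(NC(=O)CCl)c(C)c3)nc2c1` is not yet measured; it differs from compound 3 by methyl in place of chloro on an aromatic carbon, the same change as between compound 2 and compound 1. Resting on the step of a 1.2-fold higher number from compound 2 to compound 1 (0.09 log units; within the scatter), a comparable step is expected here, a step that the limit leaves unreadable from compound 3 to compound 4. Compound 4 is therefore expected near 150000 nM, most likely again returned as a limit.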

Compound 4, half-maximal inhibitory concentration: 97600 nM
The estimate for compound 4 lay 1.5-fold (0.19 log units) above the measured number; the measured number falls inside the stated range.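

The change methyl in place of chloro on an aromatic carbon can now be set side by side on two cores in this assay: the same change on two cores in this assay, a 1.2-fold higher number (0.09 log units; within the scatter) from compound 2 to compound 1 and an at least 1.0-fold lower number (0.01 log units; that floor lies within the scatter) from compound 3 to compound 4; the limit leaves it open whether they differ

The new step, an at least 1.0-fold lower number from compound 3 to compound 4 (0.01 log units; that floor lies within the scatter), is a floor and not a measured size. Compound 3 gives only a limit, > 100000 nM; the results are compatible with the change carrying over between these cores, but they do not establish it.

The compounds shown leave open how fluoro or methoxy in the same place would read against chloro and methyl. They also leave open whether a morpholine in place of the piperazine would alter the reading on either core.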